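The source may report more compounds than this note shows. Statements on the series, on what has been measured and on what is new or still open speak of the compounds shown alone.

Compound 1 `Cc1ccc(CN(C)C(=O)c2nn(-c3ccc(F)cc3)c(OC[C@@H](O)C[C@@H](O)CC(=O)O)c2C(C)C)cc1` carries a methyl(4-methylbenzyl)carbamoyl group on its core, and in a functional assay on L6 cells (Rattus norvegicus) for inhibition (on this read-out higher numbers stand for weaker inhibition and lower numbers for stronger inhibition), compound 1 gives 1250 nM. Among the measured compounds shown here, compound 2 `CC(C)c1c(C(=O)N2CCCCC2)nn(-c2ccc(F)cc2)c1OC[C@@H](O)C[C@@H](O)CC(=O)O` is its only measured neighbour; in this assay compound 2 gives 32200 nM. For the measured compounds named here, compound 1 therefore stands at the lowest of the two numbers recorded, and the single measured step, a 26-fold higher number from compound 1 to compound 2 (1.41 log units; beyond the scatter), shows that exchanging the whole amine part of the amide moves the read-out a long way.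

Compound 3 `CC(C)c1c(C(=O)N(C)Cc2cccc(Cl)c2)nn(-c2ccc(F)cc2)c1OC[C@@H](O)C[C@@H](O)CC(=O)O` keeps the benzylic amide and changes only the aryl substituent: 3-chlorophenyl in place of 4-methylphenyl on a saturated chain carbon bound to an amide-type nitrogen. Going by the values given here, no measured step addresses this kind of change; the step from compound 1 to compound 2 concerns a much larger replacement and so speaks only indirectly, suggesting the amide portion matters but saying nothing about a halogen for a methyl on the ring. Without direct precedent he expects compound 3 to show a step of a 1.2-fold higher number from compound 1 to compound 3 (0.08 log units; within the scatter), within the usual scatter, and estimates for compound 3 a value of 1500 nM, ranging from 500 nM to 4500 nM.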

Compound 3, half-maximal inhibitory concentration: 2120 nM
Estimate against measurement, compound 3: 1.4-fold (0.15 log units) below, and the stated range covers the measured number.
By their numbers in this assay, from the lowest: compounds 1 and 3 (each within the scatter of the next); then compound 2.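

The exchange of 4-methylphenyl for 3-chlorophenyl on a saturated chain carbon bound to an amide-type nitrogen gives a 1.7-fold higher number from compound 1 to compound 3 (0.23 log units; within the scatter), so in this assay a chlorine-bearing aryl group at this place reads the same as the methyl-bearing one, something the earlier replacement of the whole amine part could not show. The second step, a 15-fold lower number from compound 2 to compound 3 (1.18 log units; beyond the scatter), shows that the large gap to the piperidin-1-yl amide of compound 2 does not rest on compound 1 alone: with compound 3, both methyl(benzyl)amino amides shown stand far from compound 2, and none of the three compounds goes against this. Nothing in the data shown gives a reason for either step.

The chlorine and the methyl differ both in the substituent and in the place printed in their names, so the compounds shown leave those two changes unseparated, and 3-methylbenzyl or 4-chlorobenzyl would be needed to pull them apart. They also leave open how an unsubstituted benzyl group would read here, and whether the methyl on the amide nitrogen could give way to the amide hydrogen.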